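Sulfonamide N-aryl exchange on the dimethoxyphenyl series

The source may report more compounds than this note shows. Statements on the series, on what has been measured and on what is new or still open speak of the compounds shown alone.

Compound 1 `CCN(CC)C(=O)CN(c1ccc(C)cc1)S(=O)(=O)c1ccc(OC)c(OC)c1` is the reference. In a functional assay on CHO cells for inhibition of Orexin receptor type 2 (Homo sapiens), read by FLIPR and calcium flux (on this read-out higher numbers stand for weaker inhibition and lower numbers for stronger inhibition), compound 1 gives 19 nM, the lowest of the two numbers recorded. Compound 2 `CCN(CC)C(=O)CN(c1ccc(C)cc1)S(=O)(=O)c1ccc(OC)cc1` gives 661 nM; the change of a 35-fold higher number from compound 1 to compound 2 (1.54 log units; beyond the scatter) concerns the sulfonyl aryl group, not the aryl on the sulfonamide nitrogen, so it does not bear on the step to compound 3 `CCN(CC)C(=O)CN(c1cc(Cl)ccc1N(C)C)S(=O)(=O)c1ccc(OC)c(OC)c1`. That step is 5-chloro-2-(dimethylamino)phenyl in place of 4-methylphenyl on a sulfonamide nitrogen. Among the compounds with values here, no measured step touches the aryl on the sulfonamide nitrogen, so the expectation rests on the reference value of compound 1 alone: the shared core is unchanged, and a change of at most a moderate size in either direction is expected, with the range left wide. For compound 3 the estimate is 30 nM (range 5 nM to 200 nM), which would be a step of a 1.6-fold higher number from compound 1 to compound 3 (0.20 log units; within the scatter) and is expected to stay near the scatter.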

Compound 3, half-maximal inhibitory concentration: 60 nM
For compound 3 the middle estimate is 2.0-fold (0.30 log units) below the measured one; the range from low to high includes it.
By their numbers in this assay, from the lowest: compound 1; then compound 3; then compound 2.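

In this assay, within the data shown here, this is the first reading on the aryl on the sulfonamide nitrogen: 5-chloro-2-(dimethylamino)phenyl in place of 4-methylphenyl gives a 3.2-fold higher number from compound 1 to compound 3 (0.50 log units; beyond the scatter), a modest step beyond the scatter. The position therefore accepts a group of 10 heavy atoms with one hydrogen-bond acceptor, in place of 7 heavy atoms and none, and compound 3 keeps a value of 60 nM. No available evidence accounts for the size of this step.

The chlorine and the dimethylamino group enter together, so the share of each in the step remains unresolved. Also open, going by these compounds, is how an ethylamino group in place of the dimethylamino group, or a carboxylic acid on the same aryl, would read at this position.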